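Swapping Piperidin-1-yl for Thiomorpholin-4-yl: Stability Outlook

The source may report more compounds than this note shows. Statements on the series, on what has been measured and on what is new or still open speak of the compounds shown alone.

Measured compounds:
Compound 1, `CC(C)(C)c1cc(NC(=O)[C@@H]2CCCCN2C(=O)CC2CCOCC2)no1`, in an ADME assay (liver) for metabolic stability, with Liver microsome (Homo sapiens) as the target, read by LC-MS, using microsomes and NADPH, tested at 1 uM (a higher number here means that the compound lasts longer, a lower number that the compound disappears faster), compound 1 gives 1.83 h.
Compound 2, `CC(C)(C)c1cc(NC(=O)[C@@H]2CCCCN2C(=O)N2CCCCC2)no1`, in this assay compound 2 gives 0.233 h.

Within the data shown here, compound 2 holds the lower of the two numbers seen so far; the only measured step is a 7.9-fold lower number from compound 1 to compound 2 (0.90 log units; beyond the scatter), which set it apart from compound 1 by more than the scatter. Compound 3, `CC(C)(C)c1cc(NC(=O)[C@@H]2CCCCN2C(=O)N2CCSCC2)no1`, has not yet been measured. It differs from compound 2 by thiomorpholin-4-yl in place of piperidin-1-yl on a carbonyl carbon. Among the measured compounds shown here, no measured step bears on this change: the step from compound 1 to compound 2 swapped a ring attached through a carbon for one attached through nitrogen, whereas here one nitrogen-linked ring gives way to another of the same size, and nothing in the data shows how such an exchange moves this assay. With no guidance, the step is expected to stay within the scatter, a 1.2-fold lower number from compound 2 to compound 3 (0.07 log units; within the scatter), with compound 3 expected near 0.2 h, between 0.07 h and 0.5 h.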

Compound 3, half-life: < 0.0834 h
Compound 3 was reported as a limit; the forecaster's own chance of this, stated with the estimate: 5%; at least 2.3-fold (0.37 log units) between middle value and limit.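

The exchange of one nitrogen-linked six-membered ring for another is not a neutral change on this carbonyl carbon: in this assay, thiomorpholin-4-yl in place of piperidin-1-yl gives an at least 2.7-fold lower number from compound 2 to compound 3 (0.44 log units; beyond the scatter). Set against the (oxan-4-yl)methyl group at the same place, thiomorpholin-4-yl gives an at least 21-fold lower number from compound 1 to compound 3 (1.34 log units; beyond the scatter), so both compounds with a ring attached through nitrogen now stand lower than compound 1, the only one shown with a ring attached through carbon. The number for compound 3 is a limit of the assay and not a measured half-life: the limit of < 0.0834 h in this assay, at which 1 of the 3 values shown sits.

The compounds shown leave open whether the step follows the sulfur atom itself, a question that morpholin-4-yl, with oxygen in the place of that sulfur, or the 1,1-dioxide of thiomorpholin-4-yl would address on the same carbonyl carbon. They also leave open whether sulfur is tolerated when the ring is attached through carbon, as in a (thian-4-yl)methyl group, which could be read directly against compound 1 at 1.83 h.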